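The source may hold more compounds than are shown below. What is called first, only, known or untested is meant among the compounds shown, and "the series" means these compounds.

In a physicochemical assay for solubility, in phosphate buffer, with a stated time of 24 h, at pH 7.4, tested at 100 uM (on this read-out higher numbers stand for higher solubility and lower numbers for lower solubility), three compounds sharing a core have been measured so far. Compound 1 `O=C(NCc1ccc(S(=O)(=O)c2ccccc2)cc1)N1Cc2cccnc2C1` gives 144000 nM, compound 2 `CCCn1cc(S(=O)(=O)c2ccc(CNC(=O)N3Cc4ccncc4C3)cc2)cn1` gives 105000 nM, and compound 3 `CC(C)n1cc(S(=O)(=O)c2ccc(CNC(=O)N3Cc4ccncc4C3)cc2)cn1` gives 192000 nM. Compound 2 does not stand clear of either neighbour, since its gaps to compound 1 and to compound 3 both lie within the usual scatter of repeated measurements.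

Compound 4 `CCC(=O)N1CCC(S(=O)(=O)c2ccc(CNC(=O)N3Cc4ccncc4C3)cc2)CC1` has not been measured. It differs from compound 2 at one place, with 1-propanoylpiperidin-4-yl in place of 1-propyl-1H-pyrazol-4-yl on a sulfonyl sulfur. Among the compounds with values here, only one measured step bears on this change, and only loosely: a 1.8-fold higher number from compound 2 to compound 3 (0.26 log units; within the scatter). That step, isopropyl in place of propyl on an aromatic nitrogen, alters the group that leaves here. Within the data shown here, no measured compound carries the entering ring, so the data give no direct guide to its effect. No step beyond the scatter is therefore expected in this assay, in either direction. The expected change is a 1.1-fold higher number from compound 2 to compound 4 (0.06 log units; within the scatter). For compound 4 the estimated value is 120000 nM, with an expected range from 55000 nM to 210000 nM.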

Compound 4, solubility: 216000 nM
Compound 4: middle estimate off by 1.8-fold (0.26 log units), on the low side; the whole stated range lies below it.
By their numbers in this assay, from the lowest: compounds 2, 1, 3 and 4 (each within the scatter of the next, the first and the last beyond it).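

In this assay, a non-aromatic ring on the sulfonyl sulfur gives a result that the two pyrazole compounds could not show: 1-propanoylpiperidin-4-yl in place of 1-propyl-1H-pyrazol-4-yl gives a 2.1-fold higher number from compound 2 to compound 4 (0.31 log units; beyond the scatter), a modest step and the only one here beyond the scatter. The same ring in place of 1-isopropyl-1H-pyrazol-4-yl gives a 1.1-fold higher number from compound 3 to compound 4 (0.05 log units; within the scatter), so the exchange stands out against only one of the two aromatic groups. No measurement shown here explains why the numbers fall this way.

It remains open whether the propanoyl group matters, as no compound shown has an acetyl group or a free amine in its place on the six-membered ring. Also open, from the compounds shown here alone, is how a plain open chain, such as hexyl, would behave on the sulfonyl sulfur.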